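The compounds below may be only part of what the source reports. "The series", "measured", "known", "first", "only" and "open" are said of these compounds alone.

Measured compounds:
- compound 1 `COc1ccccc1C(=O)Nc1cccc(-c2oc3cc(-c4ccc(F)cc4)ccc3c(=O)c2O)c1`: 6370 nM
- compound 2 `CCc1ccc(C(=O)Nc2cccc(-c3oc4cc(-c5ccc(F)cc5)ccc4c(=O)c3O)c2)cc1`: 24600 nM
- compound 3 `Cc1cc(C(=O)Nc2cccc(-c3oc4cc(-c5ccc(F)cc5)ccc4c(=O)c3O)c2)ccc1F`: 12100 nM

The three compounds share one core and differ only in the aryl group attached to the amide carbonyl. In a functional assay on GTL 16 cells for antiproliferative activity against GTL 16 cell line (Homo sapiens), read by CCK-8 assay, with a stated time of 72 h (on this read-out lower numbers stand for stronger inhibition and higher numbers for weaker inhibition), compound 3 stands second highest of the three numbers; it is nearest to compound 1, and the two lie within the scatter of each other, so nothing can be said about their order. The step of a 2.0-fold lower number from compound 2 to compound 3 (0.31 log units; beyond the scatter) is modest but beyond the scatter, and a 3.9-fold higher number from compound 1 to compound 2 (0.59 log units; beyond the scatter) is the largest change seen among these aryl swaps.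

Compound 4 `COc1cc(OC)cc(C(=O)Nc2cccc(-c3oc4cc(-c5ccc(F)cc5)ccc4c(=O)c3O)c2)c1` is not yet measured. It differs from compound 3 in one place: 3,5-dimethoxyphenyl in place of 4-fluoro-3-methylphenyl on a carbonyl carbon. All three measured steps bear on this change, since each of them also swaps the aryl group on the carbonyl carbon, and none of them moved the number by more than a modest amount. A step of similar size is therefore expected here, with no clear direction. For compound 4 the estimate in this assay is 10000 nM, with a range from 4000 nM to 30000 nM, which means the expected step of a 1.2-fold lower number from compound 3 to compound 4 (0.08 log units; within the scatter).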

Compound 4, half-maximal inhibitory concentration: 19600 nM
Beside the measured number, compound 4's estimate is 2.0-fold (0.29 log units) below it; low and high end bracket the measured number.
By their numbers in this assay, from the lowest: compounds 1, 3, 4 and 2 (each within the scatter of the next, the first and the last beyond it).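

In this assay, placing 3,5-dimethoxyphenyl on the carbonyl carbon gives a 1.6-fold higher number from compound 3 to compound 4 (0.21 log units; within the scatter) and a 1.3-fold lower number from compound 2 to compound 4 (0.10 log units; within the scatter), so a group with two hydrogen-bond acceptors cannot be told apart here from 4-fluoro-3-methylphenyl, which has none, or from 4-ethylphenyl. Against the 2-methoxyphenyl group there is a 3.1-fold higher number from compound 1 to compound 4 (0.49 log units; beyond the scatter), which shows that the presence of methoxy groups on this aryl ring does not by itself settle the number, since these two methoxy-bearing compounds lie beyond the scatter of each other. No supporting measurement is available to explain these differences.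

The compounds shown leave open whether an aryl ring is needed on this carbonyl carbon at all. They also leave open how a pyridine ring, or a phenyl ring carrying an amine or a carboxylic acid, would behave at this position.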